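The source may report more compounds than this note shows. Statements on the series, on what has been measured and on what is new or still open speak of the compounds shown alone.

Measured so far:
- compound 1 `O=C(/C=C/c1coc2cc(O)ccc2c1=O)NCc1ccccc1`: > 100000 nM
- compound 2 `COc1ccc2c(=O)c(/C=C/C(=O)Nc3ccccc3Cl)coc2c1`: 29900 nM
- compound 3 `COc1ccc(NC(=O)/C=C/c2coc3cc(O)ccc3c2=O)cc1`: 12800 nM

In a functional assay on A549 cells (Homo sapiens) for inhibition, read by MTT assay, with a stated time of 48 h (on this read-out higher numbers stand for weaker inhibition and lower numbers for stronger inhibition), compound 1 reaches only the limit > 100000 nM, so no number is known for it. In this assay compound 2 gives 29900 nM, the higher of the two numbers shown. Compound 3 gives 12800 nM, and the gap between compound 3 and compound 2 is beyond the scatter.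

Within the data shown here, the one step that has been measured in full, an at least 7.8-fold lower number from compound 1 to compound 3 (0.89 log units; beyond the scatter), shows that 4-methoxyphenyl on the amide-type nitrogen gives a clearly lower number than benzyl, though the size is known only as a lower bound because of the limit of > 100000 nM in this assay, at which 1 of the 3 values shown sits.

Compound 4 `COc1ccc(CNC(=O)/C=C/c2coc3cc(OC)ccc3c2=O)cc1` is not yet measured. It differs from compound 2 by 4-methoxybenzyl in place of 2-chlorophenyl on an amide-type nitrogen. This change runs opposite in kind to the measured step: an aryl group on the amide-type nitrogen is replaced by a benzyl-type group. On that basis the number for compound 4 in this assay is expected to rise, with a 2.0-fold higher number from compound 2 to compound 4 (0.30 log units; within the scatter) as the expected step, and the estimate for compound 4 is 60000 nM within 20000 nM to 150000 nM. The methoxy group on the shared core of compound 2 and compound 4, as against the hydroxy of compound 1 and compound 3, leaves this expectation uncertain.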

Compound 4, half-maximal inhibitory concentration: 22500 nM
For compound 4 the middle estimate is 2.7-fold (0.43 log units) above the measured one; the range from low to high includes it.
By their numbers in this assay, from the lowest: compounds 3, 4 and 2 (each within the scatter of the next, the first and the last beyond it). At a limit, above all of these: compound 1.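

In this assay, 4-methoxybenzyl in place of 2-chlorophenyl on the amide-type nitrogen gives a 1.3-fold lower number from compound 2 to compound 4 (0.12 log units; within the scatter), so this pair shows no separation between a benzyl-type group and an aryl group at this position. Among these compounds, the only earlier change at this nitrogen, an at least 7.8-fold lower number from compound 1 to compound 3 (0.89 log units; beyond the scatter), favoured the aryl group, and the new pair does not follow that pattern. Compound 1 and compound 3 carry a hydroxy group on the shared core, whereas compound 2 and compound 4 carry a methoxy group, and their aryl and benzyl groups also differ, so the two steps do not show whether the core or the ring substituents account for the contrast.

On these data alone, the effect of an amine or a carboxylic acid on the ring at this nitrogen, or of a longer chain linking the ring to the nitrogen, remains open. The full size of the step from benzyl to 4-methoxyphenyl also remains unknown because of the following: the limit of > 100000 nM in this assay, at which 1 of the 4 values shown sits.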